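A few compounds are considered here, and "the series" means these few. Any claim that something is new, unique, unknown or untested is made for them only; others in the source may bear on it.

Three compounds of this series have a number in a functional assay on U-937 cells (Homo sapiens) for antiproliferative activity, read by MTT assay; a higher number here means a weaker inhibitor, a lower number a stronger inhibitor. Compound 1 `COc1ccc2nc(N(Cc3cc(-c4ccc(SC(F)(F)F)cc4)no3)c3nc4ccc(F)cc4s3)sc2c1` gives 42900 nM in this assay. Compound 2 `C#CCN(c1ncccn1)c1nc2ccccc2s1` gives 15700 nM in this assay. Compound 3 `FC(F)(F)Sc1ccc(-c2cc(CN(c3ncccn3)c3nc4ccccc4s3)on2)cc1` gives 19400 nM in this assay. Among these three numbers, compound 3 and compound 2 lie within the usual scatter of each other, so nothing separates them; compound 1 sits at a higher number than compound 3, and that gap lies beyond the scatter. All three are weak inhibitors in this assay. Among the compounds with values here, no two of the measured compounds differ in one place only, so no single step has been measured in this set.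

Compound 4 `Fc1ccccc1-c1cc(CN(c2ncccn2)c2nc3ccccc3s2)on1` is not yet measured in this assay. It differs from compound 3 in one place: 2-fluorophenyl in place of 4-((trifluoromethyl)sulfanyl)phenyl on an aromatic carbon. The rest of the molecule is that of compound 3. Nothing measured bears on a change of this kind, since compound 1, compound 2 and compound 3 each differ from the others in more than one place. Compound 4 is therefore expected to give a number close to that of compound 3 in this assay. The expected step is a 1.1-fold higher number from compound 3 to compound 4 (0.05 log units; within the scatter), which stays within the scatter. For compound 4 the estimate in this assay is 22000 nM, with a range from 8000 nM to 60000 nM.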

Compound 4, half-maximal inhibitory concentration: 27600 nM
Beside the measured number, compound 4's estimate is 1.3-fold (0.10 log units) below it, within the range that was stated.
By their numbers in this assay, from the lowest: compounds 2, 3, 4 and 1 (each within the scatter of the next, the first and the last beyond it).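

In this assay the series now has its first single-place step at this position, a 1.4-fold higher number from compound 3 to compound 4 (0.15 log units; within the scatter), which replaces 4-((trifluoromethyl)sulfanyl)phenyl with 2-fluorophenyl on the aromatic carbon next to the ring nitrogen of the five-membered aromatic ring with 1 nitrogen and 1 oxygen. The entering group has fewer heavy atoms than the leaving group and carries no sulfur and no hydrogen-bond acceptor, yet this pair of compounds is not separated in this read-out, and both remain weak inhibitors. No measurement at hand bears on why the two groups read alike.

This is a single pair at a single position, so it does not show whether a carboxylic acid or an amine on that phenyl ring, or a longer alkyl chain in place of the ring, would also stay within the scatter of compound 3. On these data alone, whether the same exchange would read alike on the core of compound 1 also remains open.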